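A few compounds are considered here, and "the series" means these few. Any claim that something is new, unique, unknown or untested is made for them only; others in the source may bear on it.

Compound 3 `C=C1/C(=C\C=C(/CCCC)c2cccc(CCCCCC(C)(C)O)c2)C[C@@H](O)C[C@@H]1O` gives 9 nM in an assay on MCF7 cells for agonist activity at vitamin D3 receptor (Homo sapiens), read by a luciferase reporter, with a stated time of 24 h (a higher number here means that more compound is needed for the effect, a lower number that less compound is needed), the highest of the three numbers measured, though the other two lie within the scatter of it: compound 2 `C=C1/C(=C\C=C(/CCC)c2cccc(CCCCCC(C)(C)O)c2)C[C@@H](O)C[C@@H]1O` gives 8.6 nM and compound 1 `C=C1/C(=C\C=C(/CC)c2cccc(CCCCCC(C)(C)O)c2)C[C@@H](O)C[C@@H]1O` gives 5.6 nM. Compound 4 `C=C1/C(=C\C=C(/CCCCCC)c2cccc(CCCCCC(C)(C)O)c2)C[C@@H](O)C[C@@H]1O` carries ethyl in place of hydrogen on a saturated chain carbon, four bonds along the chain from a double-bonded chain carbon, a further lengthening of the same chain. Within the data shown here, the steps that bear on this were a 1.5-fold higher number from compound 1 to compound 2 (0.19 log units; within the scatter), a 1.6-fold higher number from compound 1 to compound 3 (0.21 log units; within the scatter) and a 1.0-fold higher number from compound 2 to compound 3 (0.02 log units; within the scatter), none of them beyond the scatter. A further extension is therefore expected to shift this assay little, if at all, and the working expectation is a step of about a 1.2-fold higher number from compound 3 to compound 4 (0.09 log units; within the scatter). Compound 4 is estimated at 11 nM, with a range of 5 nM to 25 nM.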

Compound 4, half-maximal effective concentration: 10 nM
For compound 4 the middle estimate is 1.1-fold (0.04 log units) above the measured one, and the stated range covers the measured number.
By their numbers in this assay, from the lowest: compounds 1, 2, 3 and 4 (each within the scatter of the next).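

In this assay, the chain tolerates additions of every size shown: ethyl gives a 1.1-fold higher number from compound 3 to compound 4 (0.05 log units; within the scatter) and propyl gives a 1.2-fold higher number from compound 2 to compound 4 (0.07 log units; within the scatter) while butyl gives a 1.8-fold higher number from compound 1 to compound 4 (0.25 log units; within the scatter). Even the largest change in the series therefore stays within the scatter, so this position shows no measurable sensitivity to chain length over compounds 1 to 4. No available data explain this flat response. Still open, on these data alone, is whether a longer chain would keep this flat response, and whether an amine or a carboxylic acid in place of the ethyl would shift the number.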